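One Chlorine Moved, Then a Second One Added

The compounds below may be only part of what the source reports. "The series", "measured", "known", "first", "only" and "open" are said of these compounds alone.

Three compounds have been tested in a functional assay on NCI-H460 cells (Homo sapiens) for cytotoxicity, read by MTT assay, with a stated time of 72 h; a higher number here means a weaker inhibitor, a lower number a stronger inhibitor:

- compound 1 `CCN(CC)Cc1ccc2nc(NC(=O)N/N=C/c3cn(Cc4ccccc4Cl)c4ccccc34)sc2c1` gives 980 nM
- compound 2 `CC1CCN(Cc2ccc3nc(NC(=O)N/N=C/c4cn(Cc5ccc(Cl)cc5Cl)c5ccccc45)sc3c2)CC1` gives 1660 nM
- compound 3 `CCN(CC)Cc1ccc2nc(NC(=O)N/N=C/c3cn(Cc4cccc(Cl)c4)c4ccccc34)sc2c1` gives 220 nM

Compound 3 has the lowest number of the three, and both its gaps, to compound 1 and to compound 2, lie beyond the scatter, so it is the strongest inhibitor measured so far. For the measured compounds named here, the single step within this set is a 4.5-fold lower number from compound 1 to compound 3 (0.65 log units; beyond the scatter), a modest change that comes from moving one chlorine on the ring bound to the saturated chain carbon.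

Compound 4 `CCN(CC)Cc1ccc2nc(NC(=O)N/N=C/c3cn(Cc4ccc(Cl)cc4Cl)c4ccccc34)sc2c1` differs from compound 3 in one place: 2,4-dichlorophenyl in place of 3-chlorophenyl on a saturated chain carbon bound to an aromatic nitrogen. The new group keeps a chlorine at the 2-position, the arrangement seen in compound 1, and adds a second chlorine. Compound 2 also carries 2,4-dichlorophenyl, though with a different amine, and shows a high number. Because of a 4.5-fold lower number from compound 1 to compound 3 (0.65 log units; beyond the scatter) the step is expected to go back toward a higher number, a 5.0-fold higher number from compound 3 to compound 4 (0.70 log units; beyond the scatter). Compound 4 is therefore estimated at 1100 nM, within 400 nM to 3000 nM.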

Compound 4, half-maximal inhibitory concentration: 1080 nM
Compound 4: middle estimate off by 1.0-fold (0.01 log units), on the high side; the measured number falls inside the stated range.
By their numbers in this assay, from the lowest: compound 3; then compounds 1, 4 and 2 (each within the scatter of the next).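

In this assay, the step to 2,4-dichlorophenyl gives a 4.9-fold higher number from compound 3 to compound 4 (0.69 log units; beyond the scatter) and so shows that the low number of compound 3 does not survive this change at this place. Chloro in place of hydrogen on the 2-chlorophenyl ring gives a 1.1-fold higher number from compound 1 to compound 4 (0.04 log units; within the scatter) and lies within the scatter, so this second chlorine has no readable effect here. With 2,4-dichlorophenyl held constant, diethylamino in place of 4-methylpiperidin-1-yl gives a 1.5-fold lower number from compound 2 to compound 4 (0.19 log units; within the scatter) and also lies within the scatter, so this amine swap is not resolved on that ring.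

No measurement available here explains why compound 3 stands apart. Going by these compounds, it remains open how 3-bromophenyl or 3-methoxyphenyl would read at this place, and whether 3-chlorophenyl keeps its low number with 4-methylpiperidin-1-yl as the amine.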